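Antagonist potency after swapping the group on the ring nitrogen

This account rests on a few compounds, and the source may have more. Where it says the series, first, only, none or still open, it means among the compounds named here.

Measured compounds in an assay on HEK-293T cells for antagonist activity at vitamin D3 receptor (Homo sapiens), read by a luciferase reporter, with a stated time of 24 h; a lower number here means a stronger inhibitor, a higher number a weaker inhibitor:
- compound 1, `CC(C)c1onc(-c2c(Cl)cccc2Cl)c1COc1ccc(-c2nc3ccc(C(=O)O)cc3n2CC(C)(C)C)cc1`, gives 861 nM
- compound 2, `CC(C)c1onc(-c2c(Cl)cccc2Cl)c1COc1ccc(-c2nc3ccc(C(=O)O)cc3n2-c2ccc(F)cc2)cc1`, gives 2410 nM

Compound 2 stands at the highest of the two numbers measured in this assay. Among the measured compounds shown here, its only neighbour among the measured compounds is compound 1, and the change between them is 4-fluorophenyl in place of neopentyl on an aromatic nitrogen, which gave a 2.8-fold higher number from compound 1 to compound 2 (0.45 log units; beyond the scatter).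

Compound 3, `CC(C)c1onc(-c2c(Cl)cccc2Cl)c1COc1ccc(-c2nc3ccc(C(=O)O)cc3n2C2CC2)cc1`, has not yet been measured in this assay. It differs from compound 2 in one place: cyclopropyl in place of 4-fluorophenyl on an aromatic nitrogen.

For the measured compounds named here, only one measured step bears on this change, a 2.8-fold higher number from compound 1 to compound 2 (0.45 log units; beyond the scatter), and it was modest but beyond the scatter. Since neopentyl and cyclopropyl are both saturated carbon groups, and the aryl group gave the higher number on going from compound 1 to compound 2, the return to a saturated group is expected to lower the number again, so compound 3 is estimated to show a step of a 2.0-fold lower number from compound 2 to compound 3 (0.30 log units; within the scatter). Compound 3 is therefore expected to give 1200 nM in this assay, within a range from 500 nM to 3000 nM.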

Compound 3, half-maximal inhibitory concentration: 3200 nM
Beside the measured number, compound 3's estimate is 2.7-fold (0.43 log units) below it; the whole stated range lies below it.
By their numbers in this assay, from the lowest: compound 1; then compounds 2 and 3 (each within the scatter of the next).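

In this assay, cyclopropyl in place of 4-fluorophenyl on the aromatic nitrogen gave a 1.3-fold higher number from compound 2 to compound 3 (0.12 log units; within the scatter), so a group of 3 heavy atoms with a three-membered non-aromatic ring and one of 7 heavy atoms with a six-membered aromatic ring could not be told apart at this position. Cyclopropyl in place of neopentyl gave a 3.7-fold higher number from compound 1 to compound 3 (0.57 log units; beyond the scatter) and thus left compound 1 as the strongest inhibitor of the three, and compound 3 goes against any split of this position into saturated carbon groups and aromatic groups, since it stands with compound 2 rather than with compound 1. Nothing available explains why neopentyl stands apart from the other two groups.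

The three compounds leave open whether the lower number belongs to neopentyl alone or would also appear with other open carbon groups such as isobutyl, tert-butyl or a longer chain such as n-hexyl. They also leave open how a larger saturated ring such as cyclohexyl, or a chain ending in an amine, would read at this nitrogen.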